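A few compounds are considered here, and "the series" means these few. Any claim that something is new, unique, unknown or untested is made for them only; others in the source may bear on it.

Within the data shown here, compound 2 `CC1(Cc2ccccc2C(F)(F)F)CC(S(=O)(=O)c2ccc(F)cc2)=C(c2ccc(/C(N)=N/O)cc2)O1` stands highest of the two numbers so far in an ADME assay on cells (Peritoneal macrophage, Mus musculus, strain Balb/c) for cytotoxicity, read by resazurin assay, with a stated time of 72 h; on this read-out lower numbers stand for higher toxicity in this test and higher numbers for lower toxicity in this test; compound 2 gives 105000 nM, while compound 1 `CC1(Cc2cccc(C(F)(F)F)c2)CC(S(=O)(=O)c2ccc(F)cc2)=C(c2ccc(/C(N)=N/O)cc2)O1` gives 49800 nM. Among the measured compounds shown here, the only measured step is a 2.1-fold higher number from compound 1 to compound 2 (0.32 log units; beyond the scatter), a change of a different kind. Compound 3 `CC1(Cc2cccc([N+](=O)[O-])c2)CC(S(=O)(=O)c2ccc(F)cc2)=C(c2ccc(/C(N)=N/O)cc2)O1` differs from compound 2 by 3-nitrophenyl in place of 2-(trifluoromethyl)phenyl on a saturated chain carbon bound to a saturated ring carbon. For the measured compounds named here, no measured step covers the exchange of 2-(trifluoromethyl)phenyl for 3-nitrophenyl, so only a modest downward move is expected, by a 1.8-fold lower number from compound 2 to compound 3 (0.24 log units; within the scatter). Compound 3 is therefore estimated at 60000 nM, within a range of 25000 nM to 150000 nM.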

Compound 3, half-maximal cytotoxic concentration: 86600 nM
Compound 3: middle estimate off by 1.4-fold (0.16 log units), on the low side; measured number inside the range.
By their numbers in this assay, from the lowest: compounds 1, 3 and 2 (each within the scatter of the next, the first and the last beyond it).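

In this assay both a 1.2-fold lower number from compound 2 to compound 3 (0.08 log units; within the scatter) for 3-nitrophenyl in place of 2-(trifluoromethyl)phenyl and a 1.7-fold higher number from compound 1 to compound 3 (0.24 log units; within the scatter) for nitro in place of trifluoromethyl on an aromatic carbon lie within the scatter. On a saturated chain carbon bound to a saturated ring carbon, 3-nitrophenyl therefore cannot be told apart from either trifluoromethyl-bearing group, although the step of a 2.1-fold higher number from compound 1 to compound 2 (0.32 log units; beyond the scatter) keeps those two apart. No evidence bears on what lies behind these numbers.

Going by these compounds, whether an amine or a carboxylic acid in place of nitro on an aromatic carbon would move the number beyond the scatter stays open.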